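Thiophene attachment swap in the series

A few compounds are considered here, and "the series" means these few. Any claim that something is new, unique, unknown or untested is made for them only; others in the source may bear on it.

Measured in a functional assay on HCT-15 cells (Homo sapiens) for cytotoxicity, in the presence of a further agent that is not named here (a higher number here means a weaker inhibitor, a lower number a stronger inhibitor), so far
compound 1 `Clc1ccc(-c2cc(-c3ccc(Cl)o3)cc(-c3ccsc3)n2)cc1` gives 5190 nM
compound 2 `Cc1ccc(-c2cc(-c3ccoc3)cc(-c3ccsc3)n2)cc1` gives 44800 nM
compound 3 `Clc1ccc(-c2cc(-c3ccoc3)cc(-c3cccs3)n2)cc1` gives 50000 nM

Compound 3 at 50000 nM lies within the scatter of compound 2, while compound 1 at 5190 nM lies lower, beyond the scatter of compound 3. Compound 4 `Clc1ccc(-c2cc(-c3ccoc3)cc(-c3ccsc3)n2)cc1` has thiophen-3-yl in place of thiophen-2-yl on an aromatic carbon and remains unmeasured. Among the measured compounds shown here, no measured pair isolates this swap. Compound 2 at 44800 nM also carries thiophen-3-yl and furan-3-yl, so no step beyond the scatter is expected, and no direction is favoured. The expected step of a 1.3-fold lower number from compound 3 to compound 4 (0.10 log units; within the scatter) is small. Compound 4 is estimated at 40000 nM with a range from 15000 nM to 70000 nM in this expectation.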

Compound 4, half-maximal inhibitory concentration: > 100000 nM
Compound 4: no number, only a limit; the forecaster's own chance of this, stated with the estimate: 15%; middle value at least 2.5-fold (0.39 log units) from the limit.
By their numbers in this assay, from the lowest: compound 1; then compounds 2 and 3 (each within the scatter of the next). At a limit, above all of these: compound 4.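

In this assay, compound 4 stands only as a limit, not a number: the limit of > 100000 nM in this assay, at which 1 of the 4 values shown sits.

The thiophene swap gives an at least 2.0-fold higher number from compound 3 to compound 4 (0.30 log units; that floor lies within the scatter), so its floor does not separate the two attachments at this position next to the ring nitrogen. Chloro in place of methyl gives an at least 2.2-fold higher number from compound 2 to compound 4 (0.34 log units; beyond the scatter), and furan-3-yl in place of 5-chlorofuran-2-yl gives an at least 19-fold higher number from compound 1 to compound 4 (1.28 log units; beyond the scatter), the largest of the three floors.

From the compounds shown here alone, the full size of each step stays open while compound 4 rests on a limit. Also open, going by these compounds, is what an amine or a carboxylic acid would do in place of the thiophene.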